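Replacing 2-oxopyrrolidin-1-yl with acetyl(methyl)amino: compound 2 to compound 3

The compounds below may be only part of what the source reports. "The series", "measured", "known", "first", "only" and "open" are said of these compounds alone.

Values so far in an ADME assay on microsomes from liver (Rattus norvegicus) for metabolic stability, read by LC-MS, using NADPH, with a stated time of 30 min, tested at 1 uM; on this read-out higher numbers stand for fast clearance and lower numbers for slow clearance
- compound 1 `CC(C)c1noc(N2CCC(Oc3cc(N4CCc5cc(C6CCCCC6=O)ccc54)ncn3)CC2)n1` gives 141 mL.min-1.g-1
- compound 2 `CC(C)c1noc(N2CCC(Oc3cc(N4CCc5cc(N6CCCC6=O)ccc54)ncn3)CC2)n1` gives 138 mL.min-1.g-1

Among the measured compounds shown here, compound 2 stands level with compound 1, the only other measured compound. For the measured compounds named here, the single measured step is a 1.0-fold lower number from compound 1 to compound 2 (0.01 log units; within the scatter) (2-oxopyrrolidin-1-yl in place of 2-oxocyclohexyl on an aromatic carbon).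

Compound 3 `CC(=O)N(C)c1ccc2c(c1)CCN2c1cc(OC2CCN(c3nc(C(C)C)no3)CC2)ncn1` keeps the shared core and carries acetyl(methyl)amino in place of 2-oxopyrrolidin-1-yl on an aromatic carbon, meta to a fused ring and para to a fused ring (acetyl(methyl)amino in place of 2-oxopyrrolidin-1-yl on an aromatic carbon).

Going by the values given here, only the one measured step at that same carbon bears on this change, and it stayed within the scatter. Among the compounds with values here, no measured compound carries a group without a ring at that carbon, and a single step is thin evidence. Taking compound 2 at 138 mL.min-1.g-1 as the starting point and a 1.0-fold lower number from compound 1 to compound 2 (0.01 log units; within the scatter) as the only guide, no shift beyond the scatter is expected in this assay and no direction can be favoured. An estimated step of a 1.0-fold lower number from compound 2 to compound 3 (0.01 log units; within the scatter) follows for this change. Compound 3 is estimated at 135 mL.min-1.g-1 (expected range 75 mL.min-1.g-1 to 230 mL.min-1.g-1).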

Compound 3, intrinsic clearance in microsomes in the Rattus norvegicus assay: 17 mL.min-1.g-1
The estimate for compound 3 lay 7.9-fold (0.90 log units) above the measured number, outside the stated range (below it).
By their numbers in the Rattus norvegicus assay, from the lowest: compound 3; then compounds 2 and 1 (each within the scatter of the next).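

In the Rattus norvegicus assay compound 3 gives 17 mL.min-1.g-1, and the aromatic carbon meta to a fused ring and para to a fused ring proves sensitive to the group it carries: an 8.1-fold lower number from compound 2 to compound 3 (0.91 log units; beyond the scatter), and an 8.3-fold lower number from compound 1 to compound 3 (0.92 log units; beyond the scatter). The step between the two ring-bearing groups had stayed within the scatter, so among these three compounds the split falls between 2-oxocyclohexyl and 2-oxopyrrolidin-1-yl on one side and the ring-free acetyl(methyl)amino on the other, while in a physicochemical assay for lipophilicity, measured as octanol-water partition, at pH 7.4 (on this read-out lower numbers stand for lower lipophilicity and higher numbers for higher lipophilicity), compound 2 gives 3.7 and compound 3 gives 3.7, with no change at the digits printed from compound 2 to compound 3 (within the scatter), so the clearance step has no counterpart in the distribution coefficient. Nothing available explains why opening the lactam to this acyclic amide goes with so large a step.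

Going by these compounds, three compounds cannot separate the loss of the ring from the particular makeup of acetyl(methyl)amino, so it remains open whether the low clearance would hold with acetylamino, which carries the amide hydrogen, or with a longer acyl chain on the nitrogen. On these data alone, how a simple amine or a carboxylic acid would read at this carbon also remains open, as does whether a larger lactam or a sulfonamide would fall with the ring-bearing groups or with compound 3.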